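The source may report more compounds than this note shows. Statements on the series, on what has been measured and on what is new or still open speak of the compounds shown alone.

In an ADME assay on HEL cells (Homo sapiens) for cytotoxicity, with a stated time of 3 days (a lower number here means that less compound is tolerated, a higher number that more compound is tolerated), the three measured compounds stand as follows:

Compound 1, `CCC1(Cc2ccccc2)OS(=O)(=O)C=C1OCCCCc1ccccc1`: >= 20000 nM
Compound 2, `CCC1(Cc2ccccc2)OS(=O)(=O)C=C1OCc1ccc(F)cc1`: >= 50000 nM
Compound 3, `CCC1(Cc2ccccc2)OS(=O)(=O)C=C1OCC1CCCCC1`: >= 200000 nM

The value of compound 1 is a limit of this assay, not a number, as the limit of >= 20000 nM in this assay, at which 1 of the 3 values shown sits, records. Compound 2 likewise sits at a limit, (the limit of >= 50000 nM in this assay, at which 1 of the 3 values shown sits). Compound 3 sits at a limit, (the limit of >= 200000 nM in this assay, at which 1 of the 3 values shown sits). All three share the same core and differ only in the group on a saturated chain carbon bound to an oxygen on an unsaturated carbon. The step that the two limits leave unreadable from compound 1 to compound 2 and the step that the two limits leave unreadable from compound 1 to compound 3 are not readable; both of their ends are limits. The same holds for a step that the two limits leave unreadable from compound 2 to compound 3.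

The compound not yet measured is compound 4, `CCC1(Cc2ccccc2)OS(=O)(=O)C=C1OCc1ccc(Cl)cc1`. It differs from compound 1 as follows: 4-chlorophenyl in place of 3-phenylpropyl on a saturated chain carbon bound to an oxygen on an unsaturated carbon. The measured step that comes closest is a step that the two limits leave unreadable from compound 1 to compound 2, where 4-fluorophenyl enters in the same place, and it too is unreadable. No direction or size of step in this assay can therefore be read from these data for compound 4; the likeliest outcome is another limit. Compound 4 is estimated at 50000 nM, with a range from 10000 nM to 300000 nM. The expected step is a step that the limit leaves unreadable from compound 1 to compound 4.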

Compound 4, minimum cytotoxic concentration: >= 50000 nM
Compound 4 gave a limit, no number; the forecaster's own chance of this, stated with the estimate: 85%; the middle value lies on the limit itself.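

Compound 4, like compound 1, compound 2 and compound 3, gives only a limit and not a number in this assay, so none of its steps to those compounds can be read. The compounds shown leave open where each minimum cytotoxic concentration truly lies, and whether chloro in place of fluoro on an aromatic carbon changes it at all.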